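Swapping a Bicyclic Group for an Amide on Compound 3

The compounds below may be only part of what the source reports. "The series", "measured", "known", "first", "only" and "open" are said of these compounds alone.

Of the compounds shown here, three have been tested in an assay on isolated protein for inhibition of RAC-alpha serine/threonine-protein kinase (Homo sapiens), read by HTRF, tested at 10 uM; on this read-out lower numbers stand for less inhibition and higher numbers for more inhibition at the one concentration tested (going by the name of the read-out). Compound 1 `COC[C@@H]1CCCN1C(=O)C1CCCN1c1cc(Nc2cccc(Br)c2)ncn1` gives 0% in this assay. Compound 2 `COC(=O)C(CO)NC(=O)[C@@H]1CCCN1c1nccc(Oc2cccc(C)c2)n1` gives 0% in this assay. Compound 3 `Clc1ccc2sc(CN3CCN(c4ncnc5c4CN(Cc4ccccc4)CC5)CC3)cc2c1` gives 2% in this assay. All three numbers sit close to zero, and the gaps between compound 3 and each of the other two lie within the usual scatter, so compound 3 cannot be told apart from compound 1 or compound 2: at the concentration tested, essentially no inhibition was seen for any of them.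

Compound 4 `O=C(CN1CCN(c2ncnc3c2CN(Cc2ccccc2)CC3)CC1)Nc1cc(F)ccc1F` has not yet been measured. It keeps the core of compound 3 and differs in one place: (2,5-difluorophenyl)carbamoyl in place of 5-chloro-1-benzothiophen-2-yl on a saturated chain carbon bound to an amine nitrogen in a ring. For the measured compounds named here, no step between measured compounds speaks to a change of this kind, so the expectation rests only on the flat picture seen so far. The step is expected to be a number 1 percentage points higher from compound 3 to compound 4 (within the scatter), nothing beyond the scatter. Compound 4 is therefore estimated at 3% in this assay, within a range from -8% to 15%.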

Compound 4, a percentage reported as inhibition, at one concentration (the size of the read-out at that concentration, not a potency): 0%
Compound 4: the middle estimate sits 3 percentage points above what was measured; the measured number falls inside the stated range.
By their numbers in this assay, from the lowest: compounds 1, 2, 4 and 3 (each within the scatter of the next).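

Replacing 5-chloro-1-benzothiophen-2-yl with (2,5-difluorophenyl)carbamoyl on a saturated chain carbon bound to an amine nitrogen in a ring gives, in this assay, a number 2 percentage points lower from compound 3 to compound 4 (within the scatter) and so leaves the read-out close to zero. For the compounds shown here, this is the first step at this position, and it shows that two quite different groups, one with two fused aromatic rings and no hydrogen-bond donor, the other with one aromatic ring and an amide hydrogen, cannot be told apart here. No independent measurement is available to explain this flat result.

Still open, on these data alone, is whether a carboxylic acid or a simple amine at the same place would lift the number clear of the scatter. With every value this low, these compounds offer no starting point for ranking groups at this position.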